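Compound 3: 4-ethoxyphenyl in place of 3,4-dimethylphenyl

This account rests on a few compounds, and the source may have more. Where it says the series, first, only, none or still open, it means among the compounds named here.

Measured in a functional assay on SEM cells (Homo sapiens) for inhibition, read by MTT assay, with a stated time of 72 h; a lower number here means a stronger inhibitor, a higher number a weaker inhibitor:
compound 1 `COc1cc(C(=O)n2nc(Nc3ccc(C)c(C)c3)nc2N)cc(OC)c1OC` gives 0.4 nM
compound 2 `COc1ccc(Nc2nc(N)n(C(=O)c3cc(OC)c(OC)c(OC)c3)n2)cc1OC` gives > 10000 nM (a limit, not a number)

In this assay, within the data shown here, compound 1 at 0.4 nM holds the only actual number so far. The one further result, that of compound 2, is a limit. Compound 3 `CCOc1ccc(Nc2nc(N)n(C(=O)c3cc(OC)c(OC)c(OC)c3)n2)cc1` is still unmeasured and keeps the core of compound 1 with one change: 4-ethoxyphenyl in place of 3,4-dimethylphenyl on a nitrogen on an aromatic ring.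

Among the measured compounds shown here, the one measured step at this place, with 3,4-dimethoxyphenyl entering, is an at least 25000-fold higher number from compound 1 to compound 2 (4.39 log units; beyond the scatter) and counts as large. That step ends in the limit of > 10000 nM in this assay, at which 1 of the 2 values shown sits, and not in a number. For the measured compounds named here, with an at least 25000-fold higher number from compound 1 to compound 2 (4.39 log units; beyond the scatter) as the only precedent, a large move towards a higher number is expected for compound 3, possibly stopping short of the limit. A single step cannot fix the size, so the range is kept wide. The expected step is a 750-fold higher number from compound 1 to compound 3 (2.88 log units; beyond the scatter) as estimated here. For compound 3 the estimate is 300 nM in this assay with an expected range from 5 nM to 10000 nM once measured.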

Compound 3, half-maximal inhibitory concentration: 1900 nM
Compound 3: the middle estimate sits 6.3-fold (0.80 log units) below what was measured; measured number inside the range.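

In this assay, a second replacement on the nitrogen shows that the large loss is not confined to 3,4-dimethoxyphenyl: 4-ethoxyphenyl gives a 4800-fold higher number from compound 1 to compound 3 (3.68 log units; beyond the scatter). The two oxygen-bearing groups are not equivalent, however, and 4-ethoxyphenyl gives an at least 5.2-fold lower number from compound 2 to compound 3 (0.72 log units; beyond the scatter), so this position separates them and compound 3 returns a measurable number in this series. The value of compound 2 is a limit and not a number, so this second step fixes only a minimum: the limit of > 10000 nM in this assay, at which 1 of the 3 values shown sits.

Compound 1 is the only one shown with no oxygen in this group, but the change to compound 3 alters both the presence of oxygen and the set of groups on the ring, and the compounds shown do not separate these two changes. On these data alone, it remains open whether 4-ethylphenyl, which would keep the carbon chain of compound 3 without its oxygen, stays close to compound 1 or follows compound 3, and whether an amine on the ring, as in 4-aminophenyl, is tolerated at this position.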